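Moving the Methyl on the Carboxyphenyl Ether

The source may hold more compounds than are shown below. What is called first, only, known or untested is meant among the compounds shown, and "the series" means these compounds.

Measured compounds:
compound 1 `Cc1c(OCCCCOc2ccccc2C(=O)O)ccc(C(=O)CC(C)C)c1O` — 92.4%
compound 2 `Cc1c(OCCCCOc2cccc(C(=O)O)c2)ccc(C(=O)CC(C)C)c1O` — 84.5%
compound 3 `Cc1cc(C(=O)O)ccc1OCCCCOc1ccc(C(=O)CC(C)C)c(O)c1C` — 83.9%

In an assay on HEK293 cells for positive allosteric modulation of metabotropic glutamate receptor 2 (Rattus norvegicus), read by thallium flux, with a stated time of 2.5 min (a lower number here means a smaller maximal response, a higher number a larger maximal response), compound 3 stands at the low end of the three numbers, yet its gaps to the others, a number 0.6 percentage points lower from compound 2 to compound 3 (within the scatter) and a number 8.5 percentage points lower from compound 1 to compound 3 (within the scatter), lie within the scatter, as does a number 7.9 percentage points lower from compound 1 to compound 2 (within the scatter). Compound 4 `Cc1cc(OCCCCOc2ccc(C(=O)CC(C)C)c(O)c2C)ccc1C(=O)O` differs from compound 3 by 4-carboxy-3-methylphenyl in place of 4-carboxy-2-methylphenyl on an oxygen on a saturated carbon. The three measured steps all rearrange the carboxyphenyl ether end, and none moved the read-out beyond the scatter, so a further rearrangement of the same kind is expected to leave this assay unchanged within the scatter. Compound 4 is therefore estimated at 86%, with a range of 72% to 98%, and the expected step is a number 2.1 percentage points higher from compound 3 to compound 4 (within the scatter).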

Compound 4, largest response reached (reported as percent of maximum), in percent of the reference or control that the assay uses: 93.3%
For compound 4 the middle estimate is 7.3 percentage points below the measured one; the range from low to high includes it.
By their numbers in this assay, from the lowest: compounds 3, 2, 1 and 4 (each within the scatter of the next).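

In this assay, the new arrangement, 4-carboxy-3-methylphenyl, gives a number 9.4 percentage points higher from compound 3 to compound 4 (within the scatter), together with a number 8.8 percentage points higher from compound 2 to compound 4 (within the scatter) and a number 0.9 percentage points higher from compound 1 to compound 4 (within the scatter). Across all four compounds, then, no rearrangement of this end group on an oxygen on a saturated carbon has produced a step beyond the scatter, even with the methyl in this new place. Nothing available explains this result. From the compounds shown here alone, it remains open whether a tetrazole in place of the carboxylic acid, or a longer chain between the two ether oxygens, would stay within the scatter too.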